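The compounds below may be only part of what the source reports. "The series", "measured", "known", "first", "only" and "open" are said of these compounds alone.

Compound 2 `COc1cc2c(cc1OC)C(CC(=O)NC(C)C)CC2` stands highest of the two numbers in a functional assay on the whole organism (strain Wistar) for inhibition, with Rattus norvegicus as the target, read by paw edema, with stated times of 60 min and 24 h, at a dose of 100 mg/kg by the oral route (on this read-out higher numbers stand for more inhibition at the one dose given (going by the name of the read-out) and lower numbers for less inhibition), giving 30%. Compound 1 `CCN(CC)C(=O)CC1CCc2cc(OC)c(OC)cc21` gives 16.7%, and the step of a number 13.3 percentage points higher from compound 1 to compound 2 (beyond the scatter) is the only one measured so far. Compound 3 `COc1cc2c(cc1OC)C(CC(=O)NC(C)(C)C)CC2` differs from compound 2 by methyl in place of hydrogen on a saturated chain carbon bound to an amide-type nitrogen and two saturated chain carbons. The measured step concerns the same amide part, exchanging diethylamino for isopropylamino, so it bears on this change only loosely. Compound 3 is therefore expected to show a step of a number 2 percentage points higher from compound 2 to compound 3 (within the scatter) that stays within the scatter. Compound 3 is estimated to give 32%, between 18% and 46%.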

Compound 3, a percentage reported as inhibition, in the whole organism at one dose (the size of the read-out at that dose, not a potency): 40%
For compound 3 the middle estimate is 8 percentage points below the measured one; the measured number falls inside the stated range.
By their numbers in this assay, from the lowest: compound 1; then compounds 2 and 3 (each within the scatter of the next).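

Methyl in place of hydrogen on a saturated chain carbon bound to an amide-type nitrogen and two saturated chain carbons gives a number 10 percentage points higher from compound 2 to compound 3 (within the scatter) in this assay and so does not separate isopropylamino from (tert-butyl)amino. (tert-Butyl)amino in place of diethylamino on a carbonyl carbon gives a number 23.3 percentage points higher from compound 1 to compound 3 (beyond the scatter) and thus matches the direction seen with isopropylamino. No measurement shown here accounts for either step.

Still open, going by these compounds, is how morpholine or a plain amino group would read on the carbonyl carbon. Also open, on these data alone, is whether a longer chain carrying the carbonyl would change the reading.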